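The source may hold more compounds than are shown below. What is called first, only, known or untested is meant among the compounds shown, and "the series" means these compounds.

Series notes, step from compound 2 to compound 3.

For the measured compounds named here, compound 2 `CCOC(=O)N1CCN(CCCOc2ccc(C(=O)c3ccc(F)cc3)cc2)CC1` stands at the higher end of the two numbers measured so far: in an assay on isolated protein for binding affinity to histamine H2 receptor (Homo sapiens) (on this read-out higher numbers stand for weaker inhibition and lower numbers for stronger inhibition), compound 2 gives 42700 nM. Its nearest neighbour is compound 1 `CCOC(=O)N1CCN(CCCOc2ccc(C(C)=O)cc2)CC1`, which in this assay gives 39800 nM. Going by the values given here, the single measured step, a 1.1-fold higher number from compound 1 to compound 2 (0.03 log units; within the scatter), shows that exchanging the methyl on the carbonyl carbon for a 4-fluorophenyl left the number where it was.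

Compound 3 `CCOC(=O)N1CCN(CCCOc2ccc(C(=O)c3ccc(OC)cc3)cc2)CC1` is the next compound of the set and awaits measurement in this assay. Its change from compound 2 is methoxy in place of fluoro on an aromatic carbon, a substituent exchange on the aromatic ring that hangs from the carbonyl. Among the compounds with values here, no measured step touches that ring directly; the only step on record, a 1.1-fold higher number from compound 1 to compound 2 (0.03 log units; within the scatter), built the ring itself without moving the number. On that basis the expectation is for no step beyond the scatter, and compound 3 is expected to give 40000 nM in this assay, in the range 14000 nM to 115000 nM, which corresponds to an expected step of a 1.1-fold lower number from compound 2 to compound 3 (0.03 log units; within the scatter).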

Compound 3, inhibition constant: 8320 nM
Estimate against measurement, compound 3: 4.8-fold (0.68 log units) above, outside the stated range (below it).
By their numbers in this assay, from the lowest: compound 3; then compounds 1 and 2 (each within the scatter of the next).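

In this assay, the substituent on the aromatic ring hanging from the carbonyl can move the number, which the earlier pair did not show: methoxy in place of fluoro, para to a large group, gives a 5.1-fold lower number from compound 2 to compound 3 (0.71 log units; beyond the scatter) as its step, whereas building the ring itself with fluoro gave only a 1.1-fold higher number from compound 1 to compound 2 (0.03 log units; within the scatter) as its step. Set against the methyl on the carbonyl carbon, the 4-methoxyphenyl gives a 4.8-fold lower number from compound 1 to compound 3 (0.68 log units; beyond the scatter) as its step, so among these three compounds the aromatic ring goes with a lower number only when it carries methoxy, and compound 2 with its fluoro goes against any reading that credits the ring alone. Nothing available speaks to what lies behind this step.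

From the compounds shown here alone, whether the lower number is particular to methoxy or would also appear with another group at this place, such as ethoxy, hydroxy or an amine, stays open. Going by these compounds, all three compounds share the rest of the core, so it is also open whether the exchange would give a similar step with a longer chain there.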